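Fluoro in place of methoxy on the anilino ring

This account rests on a few compounds, and the source may have more. Where it says the series, first, only, none or still open, it means among the compounds named here.

The measured compounds:
compound 1, `COC(=O)c1c(Nc2ccccc2)sc(C(=O)c2ccc(OC)cc2)c1C`, 48.1%
compound 2, `COC(=O)c1c(Nc2ccc(C)cc2)sc(C(=O)c2ccc(OC)cc2)c1C`, "not active" (no number reported)
compound 3, `COC(=O)c1c(Nc2ccc(OC)cc2)sc(C(=O)c2ccc(OC)cc2)c1C`, 20.5%

In a functional assay, with a stated time of 150 min, tested at 30 ug/mL (a higher number here means a stronger effect of the compound at the concentration tested, a lower number a weaker effect), compound 1 gives 48.1%, while compound 3 gives 20.5%. Compound 2 in this assay is reported as "not active" (no number reported), with no number given for it. Compound 3 thus stands lowest of the two compounds with a number; its nearest neighbour is compound 1, and the step of a number 27.6 percentage points lower from compound 1 to compound 3 (beyond the scatter) is beyond the scatter, so methoxy in place of hydrogen on that aromatic carbon cost a modest amount of activity.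

Compound 4, `COC(=O)c1c(Nc2ccc(F)cc2)sc(C(=O)c2ccc(OC)cc2)c1C`, has not yet been measured. It differs from compound 3 by fluoro in place of methoxy on an aromatic carbon. Among the compounds with values here, no measured step covers fluoro at this position, so the only bearing comes from the step from compound 1 to compound 3 and from the report on compound 2, which together show that a change at this carbon can move the read-out in either direction by a modest or larger amount. The estimate for compound 4 in this assay is 30%, with a range from 5% to 55%, which means an expected step of a number 9.5 percentage points higher from compound 3 to compound 4 (within the scatter).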

Compound 4, a percentage reported as activity, at one concentration (the size of the read-out at that concentration, not a potency): 23.3%
Beside the measured number, compound 4's estimate is 6.7 percentage points above it; low and high end bracket the measured number.
By their numbers in this assay, from the lowest: compounds 3 and 4 (each within the scatter of the next); then compound 1.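

In this assay, fluoro in place of methoxy on this aromatic carbon gives a number 2.8 percentage points higher from compound 3 to compound 4 (within the scatter), so at this position the two groups cannot be told apart by this read-out, even though fluoro is the smaller group by heavy-atom count. Fluoro in place of hydrogen gives a number 24.8 percentage points lower from compound 1 to compound 4 (beyond the scatter), which shows that the drop first seen with methoxy is not confined to that one group: both compounds with a number and a group at this carbon sit well under the unsubstituted compound 1, while steps involving compound 2 cannot be read, as it has no number. The data shown offer no explanation for why these two different groups give such similar results here.

From the compounds shown here alone, whether an amine or a carboxylic acid on this carbon would restore the read-out of compound 1 or lower it further remains open. Also open, going by these compounds, is whether fluoro in place of methoxy on the other 4-methoxyphenyl group, the one on the carbonyl, which all four compounds share, would be as uneventful as it is on the anilino ring.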